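The compounds below may be only part of what the source reports. "The series", "measured", "known", "first", "only" and "open" are said of these compounds alone.

Measured in a functional assay on KM12 cells (Homo sapiens) for antiproliferative activity; a higher number here means a weaker inhibitor of growth, a lower number a stronger inhibitor of growth:
- Compound 1 `COc1ccc(-c2nc3cc(F)ccc3s2)cc1C`: 18600 nM
- Compound 2 `COc1ccc(-c2nc3cc(F)ccc3s2)cc1F`: 20600 nM
- Compound 3 `COc1ccc(-c2nc3cc(F)ccc3s2)cc1Br`: not yet measured

In this assay, compound 2 stands at 20600 nM, within the scatter of compound 1. Going on to compound 3 puts bromo in place of fluoro on an aromatic carbon, ortho to a methoxy group: bromo in place of fluoro on an aromatic carbon. For the measured compounds named here, only one measured step bears on this, a swap on that same carbon: a 1.1-fold higher number from compound 1 to compound 2 (0.04 log units; within the scatter). One small step is thin evidence, but it gives no reason to expect a change beyond the scatter. The expected step is a 1.1-fold lower number from compound 2 to compound 3 (0.06 log units; within the scatter). Compound 3 is estimated at 18000 nM, with an expected range of 8000 nM to 40000 nM.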

Compound 3, concentration for 50% growth inhibition: 6700 nM
Beside the measured number, compound 3's estimate is 2.7-fold (0.43 log units) above it, outside the stated range (below it).
By their numbers in this assay, from the lowest: compound 3; then compounds 1 and 2 (each within the scatter of the next).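

In this assay, the carbon ortho to a methoxy group proves sensitive to what sits on it: bromo gives a 3.1-fold lower number from compound 2 to compound 3 (0.49 log units; beyond the scatter) and a 2.8-fold lower number from compound 1 to compound 3 (0.44 log units; beyond the scatter), whereas fluoro and methyl could not be told apart. Among these three groups, then, the position is not indifferent, and bromo stands apart from the other two. Nothing measured here explains why bromo behaves differently.

As far as these compounds go, whether chloro or iodo on this carbon would give a similar number remains open. So does the effect of an amine or a carboxylic acid there.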